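The compounds below may be only part of what the source reports. "The series", "measured", "known", "first", "only" and "open" are said of these compounds alone.

Measured so far:
compound 1 `COc1ccc([C@@H]2CC(=O)c3c(O)cc(OCc4cn(Cc5ccccc5C(F)(F)F)nn4)cc3O2)cc1O`, 12500 nM
compound 2 `CCCn1cc(COc2cc(O)c3c(c2)O[C@H](c2ccc(OC)c(O)c2)C/C3=N\O)nn1`, 2340 nM
compound 3 `COc1ccc([C@@H]2C/C(=N\O)c3c(O)cc(OCc4cn(C5CCCC5)nn4)cc3O2)cc1O`, 6880 nM

All three were run in a functional assay on RAW264.7 cells (Mus musculus) for inhibition, read by Griess assay, with stated times of 2 h and 24 h; a lower number here means a stronger inhibitor, a higher number a weaker inhibitor. Compound 1 gives the highest number of the three; its nearest neighbour is compound 3, within the scatter, and its furthest is compound 2, beyond it. Within the data shown here, the only single-site step so far is a 2.9-fold higher number from compound 2 to compound 3 (0.47 log units; beyond the scatter), a change of the group on an aromatic nitrogen, and it is modest. Compound 4 `COc1ccc([C@@H]2CC(=O)c3c(O)cc(OCc4cn(Cc5cccc(C)c5)nn4)cc3O2)cc1O` differs from compound 1 by 3-methylphenyl in place of 2-(trifluoromethyl)phenyl on a saturated chain carbon bound to an aromatic nitrogen. Among the measured compounds shown here, no measured step touches the group on the saturated chain carbon bound to an aromatic nitrogen, so there is nothing to anchor a direction. Compound 4 is therefore expected to stay within the scatter of compound 1, a step of a 1.0-fold lower number from compound 1 to compound 4 (0.02 log units; within the scatter). Compound 4 is estimated at 12000 nM in this assay, range 5000 nM to 30000 nM.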

Compound 4, half-maximal inhibitory concentration: 17400 nM
Estimate against measurement, compound 4: 1.5-fold (0.16 log units) below, and the stated range covers the measured number.
By their numbers in this assay, from the lowest: compound 2; then compounds 3, 1 and 4 (each within the scatter of the next, the first and the last beyond it).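

Moving from 2-(trifluoromethyl)benzyl to 3-methylbenzyl gives the first measured step at this position in this assay, with a 1.4-fold higher number from compound 1 to compound 4 (0.14 log units; within the scatter) as its size. This exchange of both the substituent and its place on the phenyl ring therefore sets no direction for the position. Among these compounds, no evidence on this pair is available to interpret the step.

The effects of the substituent and its place remain unseparated in this single step. Going by these compounds, whether an amine or a carboxylic acid on that phenyl ring would move the number beyond the scatter also remains open.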